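The source may hold more compounds than are shown below. What is called first, only, known or untested is meant among the compounds shown, and "the series" means these compounds.

- Compound 1 `CC1(C)[C@H]2CC[C@]1(C)N(Cc1cn(-c3ccc(C#N)cc3)nn1)C(=O)C2`: 140 nM
- Compound 2 `CC1(C)[C@H]2CC[C@]1(C)N(Cc1cn(-c3cccc(Br)c3)nn1)C(=O)C2`: 90 nM

In a functional assay on A549 cells (Homo sapiens) for inhibition, read by MTT assay, with a stated time of 24 h (a higher number here means a weaker inhibitor, a lower number a stronger inhibitor), compound 2 gives 90 nM, and compound 1 gives 140 nM. These two numbers lie within the usual scatter of each other, so neither compound can be ranked above the other.

Compound 3 `COc1cccc(-n2cc(CN3C(=O)C[C@@H]4CC[C@@]3(C)C4(C)C)nn2)c1` keeps the framework of compound 2 but carries methoxy in place of bromo on an aromatic carbon, meta to a large group: methoxy in place of bromo on an aromatic carbon.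

For the measured compounds named here, only one measured step bears on this change: a 1.6-fold lower number from compound 1 to compound 2 (0.19 log units; within the scatter). It exchanged 4-cyanophenyl for 3-bromophenyl and stayed within the scatter. Going by the values given here, no measurement yet tests methoxy directly, so this assay is expected to show no step beyond the scatter.

The estimate amounts to an expected 1.3-fold higher number from compound 2 to compound 3 (0.12 log units; within the scatter). For compound 3, the expected value is 120 nM, with an estimated range of 50 nM to 300 nM.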

Compound 3, half-maximal inhibitory concentration: 240 nM
Compound 3: middle estimate off by 2.0-fold (0.30 log units), on the low side; the measured number falls inside the stated range.
By their numbers in this assay, from the lowest: compounds 2, 1 and 3 (each within the scatter of the next, the first and the last beyond it).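

At this place on the ring, methoxy and bromo are not interchangeable in this assay: a 2.7-fold higher number from compound 2 to compound 3 (0.43 log units; beyond the scatter) is the only step shown that passes beyond the scatter, and it is a modest one. The other new step, a 1.7-fold higher number from compound 1 to compound 3 (0.23 log units; within the scatter), stays within the scatter, so compound 1 cannot be ranked against compound 3 even though compound 2 and compound 3 can be told apart. Nothing available explains why methoxy and bromo differ here.

As far as these compounds go, whether an amine, a carboxylic acid or a chloro group at this place would match compound 2 or compound 3 remains open. Also open, from the compounds shown here alone, is whether methoxy and bromo would differ in the same way elsewhere on the ring, since 4-cyanophenyl changes both the group and its place.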